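The source may report more compounds than this note shows. Statements on the series, on what has been measured and on what is new or still open speak of the compounds shown alone.

Measured compounds:
compound 1 `Nc1cc(N)c2nc(-c3ccccc3)c(Oc3ccc(Cl)c(Cl)c3)nc2c1` — < 100000 nM
compound 2 `CCOC(=O)[C@H](CCC(=O)O)NC(=O)c1ccc(CNc2nc3cc(N)cc(N)c3nc2-c2ccccc2)cc1` — < 100000 nM

Compound 1 `Nc1cc(N)c2nc(-c3ccccc3)c(Oc3ccc(Cl)c(Cl)c3)nc2c1` was run in a functional assay on RPMI8266 cells (Homo sapiens) for inhibition, read by sulforhodamine B assay, with a stated time of 48 h; a higher number here means a weaker inhibitor of growth, a lower number a stronger inhibitor of growth. Compound 1 gives < 100000 nM, which is a limit of the assay and not a number. Compound 2 `CCOC(=O)[C@H](CCC(=O)O)NC(=O)c1ccc(CNc2nc3cc(N)cc(N)c3nc2-c2ccccc2)cc1` in this assay gives < 100000 nM, also a limit. Among the measured compounds shown here, both recorded values sit at the limit of < 100000 nM in this assay, at which 2 of the 2 values shown sit, and where compound 1 stands can be said only in that sense: at the limit, with no step between measured compounds available for comparison.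

Compound 3 `Nc1cc(N)c2nc(-c3ccccc3)c(Sc3ccc(Cl)c(Cl)c3)nc2c1` has not been measured. It differs from compound 1 by (3,4-dichlorophenyl)sulfanyl in place of 3,4-dichlorophenoxy on an aromatic carbon. With both recorded values at the same limit, no step beyond the scatter is expected in this assay in either direction, and the most likely result for compound 3 is again a limit. For compound 3 the estimate in this assay is 30000 nM, in the range 5000 nM to 100000 nM. The expected step is a step that the limit leaves unreadable from compound 1 to compound 3.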

Compound 3, concentration for total growth inhibition: 31600 nM
Estimate against measurement, compound 3: 1.1-fold (0.02 log units) below; the measured number falls inside the stated range.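

No step can be read from compound 1 to compound 3, because compound 1 is recorded only as a limit: the limit of < 100000 nM in this assay, at which 2 of the 3 values shown sit.

On these data alone, whether (3,4-dichlorophenyl)sulfanyl in place of 3,4-dichlorophenoxy changes growth inhibition at all, and in which direction, stays open.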